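Fluoro for chloro on the biaryl amidine series

A few compounds are considered here, and "the series" means these few. Any claim that something is new, unique, unknown or untested is made for them only; others in the source may bear on it.

In a functional assay on NCI-H226 cells (Homo sapiens) for inhibition, read by sulforhodamine B assay, with a stated time of 48 h (on this read-out lower numbers stand for stronger inhibition of growth and higher numbers for weaker inhibition of growth), the three measured compounds stand as follows.
Compound 1 `N=C(N)c1ccc(-c2ccc(-c3cc(Cl)cc(Cl)c3)s2)s1` gives 30800 nM.
Compound 2 `N=C(N)c1ccc(-c2ccc(-c3ccc(Cl)cc3)s2)s1` gives 2190 nM.
Compound 3 `N=C(N)c1ccc(-c2ccc(-c3ccccc3)o2)o1` gives 5700 nM.

Compound 2 holds the lowest number of the three in this assay; compound 3 sits closest to it, beyond the scatter, and compound 1 lies furthest away, also beyond the scatter. Among the measured compounds shown here, no pair among the three differs in only one place, so no single structural step can be read from the measured set.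

Compound 4 `N=C(N)c1ccc(-c2ccc(-c3ccc(F)cc3)s2)s1` is not yet measured. It differs from compound 2 by fluoro in place of chloro on an aromatic carbon, the place being an aromatic carbon of a six-membered aromatic ring of carbon only, para to a large group. There is no measured comparison in this assay to show what this exchange does. The expectation for the step of a 1.4-fold higher number from compound 2 to compound 4 (0.14 log units; within the scatter) is a small one, if any, toward a higher number, and not beyond the scatter. Compound 4 is therefore estimated at 3000 nM, with a range from 1000 nM to 9000 nM, and the measurement will settle it.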

Compound 4, concentration for 50% growth inhibition: 1420 nM
Beside the measured number, compound 4's estimate is 2.1-fold (0.32 log units) above it; the range from low to high includes it.
By their numbers in this assay, from the lowest: compounds 4 and 2 (each within the scatter of the next); then compound 3; then compound 1.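

The series now has its first one-place comparison in this assay: fluoro in place of chloro on an aromatic carbon gives a 1.5-fold lower number from compound 2 to compound 4 (0.19 log units; within the scatter). At this place, para to a large group, the read-out therefore does not separate the two halogens, and the exchange leaves growth inhibition within the usual variation between repeats. No measurement is available here that bears on this result.

Still open is what this place does with a group that is not a halogen, such as an amine, a methoxy group or a carboxylic acid, since no one-place comparison of that kind is shown. Also open, from the compounds shown here alone, is whether fluoro in place of chloro gives a step of similar size on the dichloro pattern of compound 1.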